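Compound 3 to compound 4: bromomethyl becomes phenyl

The compounds below may be only part of what the source reports. "The series", "measured", "known", "first", "only" and "open" are said of these compounds alone.

In a functional assay on HL-60 cells (Homo sapiens) for cytotoxicity, read by MTT assay, with a stated time of 24 h (on this read-out lower numbers stand for stronger inhibition and higher numbers for weaker inhibition), three compounds sharing one core have been read so far. Compound 1 `OCCCOc1c(Br)cc(Br)cc1Oc1ccc(Br)cc1Br` gives 29.9 ug/mL, compound 2 `CCOC(=O)C(C)Oc1c(Br)cc(Br)cc1Oc1ccc(Br)cc1Br` gives 35.7 ug/mL and compound 3 `BrCCOc1c(Br)cc(Br)cc1Oc1ccc(Br)cc1Br` gives 26.2 ug/mL. Compound 3 therefore lies within the scatter of both others, and the three cannot be ranked.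

The next compound is compound 4 `Brc1ccc(Oc2cc(Br)cc(Br)c2OCc2ccccc2)c(Br)c1`, with phenyl in place of bromomethyl on a saturated chain carbon bound to an oxygen on an aromatic ring.

The measured steps that bear on this change all concern the group on that same oxygen: a 1.1-fold lower number from compound 1 to compound 3 (0.06 log units; within the scatter), a 1.4-fold lower number from compound 2 to compound 3 (0.13 log units; within the scatter) and a 1.2-fold higher number from compound 1 to compound 2 (0.08 log units; within the scatter). Each stays within the scatter. For the measured compounds named here, no measured compound carries a ring in that group, so the support is indirect and the range is kept wide.

No shift beyond the scatter, in either direction, is expected in this assay. The estimated step is a 1.1-fold higher number from compound 3 to compound 4 (0.03 log units; within the scatter). For compound 4 the expected value is 28 ug/mL, with an estimated range of 14 ug/mL to 56 ug/mL.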

Compound 4, half-maximal inhibitory concentration: 27.9 ug/mL
The estimate for compound 4 lay 1.0-fold (0.00 log units) above the measured number, and the stated range covers the measured number.
By their numbers in this assay, from the lowest: compounds 3, 4, 1 and 2 (each within the scatter of the next).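

Benzyl is the first group with a ring to be read on this oxygen in this assay, and phenyl in place of bromomethyl gives a 1.1-fold higher number from compound 3 to compound 4 (0.03 log units; within the scatter), so the bromine of compound 3 is not required to keep the number in this range. The comparisons with the other two compounds, a 1.3-fold lower number from compound 2 to compound 4 (0.11 log units; within the scatter) and a 1.1-fold lower number from compound 1 to compound 4 (0.03 log units; within the scatter), also stay within the scatter, so these four groups on this oxygen, with an ester, a hydroxyl, a bromine or an aromatic ring, cannot be told apart in this series. No measurement beyond these numbers bears on the result.

As far as these compounds go, whether an amine or a carboxylic acid on this oxygen would move the number beyond the scatter stays open, as does the effect of a longer chain ending in phenyl. From the compounds shown here alone, whether this flat reading holds in any other assay also stays open.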